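Fluorine for methoxy on the benzyl arm

The source may report more compounds than this note shows. Statements on the series, on what has been measured and on what is new or still open speak of the compounds shown alone.

Compound 1, `COc1cc(N)c(Cl)cc1NC(=O)C1CCN(Cc2cccc(C#N)c2)CC1`: in a functional assay on the whole organism for antagonist activity, with Mus musculus as the target (on this read-out higher numbers stand for an effect only at larger amounts of compound and lower numbers for an effect already at smaller amounts), compound 1 gives > 4 mg/kg, which is a limit of the assay and not a number.
Compound 2, `COc1cccc(CN2CCC(C(=O)Nc3cc(Cl)c(N)cc3OC)CC2)c1`: in this assay compound 2 gives > 4 mg/kg, again a limit of the assay.

Compound 2 therefore stands only at a limit, and the same holds for the other value shown, since both sit at the same limit (the limit of > 4 mg/kg in this assay, at which 2 of the 2 values shown sit). Within the data shown here, the one step between measured compounds, a step that the two limits leave unreadable from compound 1 to compound 2, cannot be sized, because both of its ends are limits. Compound 3, `COc1cc(N)c(Cl)cc1NC(=O)C1CCN(Cc2ccccc2F)CC1`, differs from compound 2 by 2-fluorophenyl in place of 3-methoxyphenyl on a saturated chain carbon bound to an amine nitrogen in a ring. Among the measured compounds shown here, no measured step of readable size bears on this change. The expected step from compound 2 to compound 3 is thus a step that the limit leaves unreadable from compound 2 to compound 3, most likely again ending at a limit rather than a number. For compound 3 the estimate in this assay is 6 mg/kg, with a range from 2 mg/kg to 30 mg/kg.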

Compound 3, dose for half-maximal effect: > 4 mg/kg
Compound 3 gave a limit, no number; the forecaster's own chance of this, stated with the estimate: 75%; the middle value is on the limit's open side.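

Compound 3 also gives only a limit of the assay, so no step among compound 1, compound 2 and compound 3 can be read: the limit of > 4 mg/kg in this assay, at which 3 of the 3 values shown sit.

The compounds shown leave open how far each lies past that limit in this assay, and whether changing the group on the benzyl arm alters the dose at all.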